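Antiproliferative notes: from compound 2 to compound 3

A few compounds are considered here, and "the series" means these few. Any claim that something is new, unique, unknown or untested is made for them only; others in the source may bear on it.

For the measured compounds named here, in a functional assay on A549 cells (Homo sapiens) for antiproliferative activity, read by MTT assay (a lower number here means a stronger inhibitor, a higher number a weaker inhibitor), compound 1 (`Cc1cccc(/C=N/Nc2ncc3c(n2)n(C2CCCC2)c(=O)c(=O)n3C)c1`) gives 34500 nM and compound 2 (`Cn1c(=O)c(=O)n(C2CCCC2)c2nc(N/N=C/c3cc([N+](=O)[O-])ccc3Cl)ncc21`) gives 8780 nM, the lower of the two numbers so far. The next change leads to compound 3 (`Cn1c(=O)c(=O)n(C2CCCC2)c2nc(N/N=C/c3ccc(F)cc3F)ncc21`): 2,4-difluorophenyl in place of 2-chloro-5-nitrophenyl on a carbon with a double bond to nitrogen. In words, 2,4-difluorophenyl stands in place of 2-chloro-5-nitrophenyl on a carbon with a double bond to nitrogen. Going by the values given here, one measured step bears on this place: a 3.9-fold lower number from compound 1 to compound 2 (0.59 log units; beyond the scatter), modest but beyond the scatter. Among the compounds with values here, no measured compound carries 2,4-difluorophenyl, so the direction is uncertain. Since compound 2 holds the lower number, a modest rise in this assay is expected, no larger than that measured step. The estimated change is a 1.8-fold higher number from compound 2 to compound 3 (0.26 log units; within the scatter). In this assay the estimate for compound 3 is 16000 nM, with an expected range from 6000 nM to 40000 nM.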

Compound 3, half-maximal inhibitory concentration: 18300 nM
Beside the measured number, compound 3's estimate is 1.1-fold (0.06 log units) below it; the range from low to high includes it.
By their numbers in this assay, from the lowest: compound 2; then compounds 3 and 1 (each within the scatter of the next).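

In this assay, 2,4-difluorophenyl gives a 2.1-fold higher number from compound 2 to compound 3 (0.32 log units; beyond the scatter), so the lower number of compound 2 does not extend to this second halogenated aryl group. Against 3-methylphenyl, the same group gives a 1.9-fold lower number from compound 1 to compound 3 (0.28 log units; within the scatter), which leaves those two groups unseparated at this position. Compound 2 is therefore the most active of the three, with its steps to both other compounds beyond the scatter. Nothing available here accounts for these differences.

On these data alone, whether the lower number of compound 2 belongs to the chlorine, to the nitro group or to the two together remains open. Also open, as far as these compounds go, is how this assay responds at this position to a phenyl group carrying an amine or a carboxylic acid.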